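This account rests on a few compounds, and the source may have more. Where it says the series, first, only, none or still open, it means among the compounds named here.

Measured in an assay on cell membranes for binding affinity to adenosine receptor A1 (Bos taurus), read by radioligand binding; on this read-out lower numbers stand for stronger inhibition and higher numbers for weaker inhibition:
compound 1 `c1ccc(Cn2nnc3c(NC4CCCC4)ncnc32)cc1` gives 127 nM
compound 2 `c1ccc(Cn2nnc3c(NCC4CCCCC4)ncnc32)cc1` gives 2790 nM
compound 3 `Clc1ccccc1Cn1nnc2c(NCC3CCCCC3)ncnc21` gives 4260 nM

Among these three, compound 3 has the highest number in this assay. Its gap to compound 2, a 1.5-fold higher number from compound 2 to compound 3 (0.18 log units; within the scatter), is within the scatter, whereas its gap to compound 1 lies well beyond it.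

Compound 4 `Cc1cccc(Nc2ncnc3c2nnn3Cc2ccccc2Cl)c1` has not yet been measured. It differs from compound 3 at the nitrogen on an aromatic ring: 3-methylphenyl in place of cyclohexylmethyl on a nitrogen on an aromatic ring. Within the data shown here, none of the measured steps replaces a saturated ring by an aromatic one, so there is no direct precedent. Among the measured compounds shown here, the only measured step that touches this same nitrogen, a 22-fold higher number from compound 1 to compound 2 (1.34 log units; beyond the scatter), was large, which shows that the group at this place can move the number strongly. The chloro step, a 1.5-fold higher number from compound 2 to compound 3 (0.18 log units; within the scatter), barely moved it. Because this change is of a different kind from a 22-fold higher number from compound 1 to compound 2 (1.34 log units; beyond the scatter), its direction cannot be read from the data, and a wide range is the honest answer. A moderate weakening is expected: a 1.4-fold higher number from compound 3 to compound 4 (0.15 log units; within the scatter). Compound 4 is therefore estimated at 6000 nM, with a range from 700 nM to 40000 nM.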

Compound 4, inhibition constant: 5880 nM
Compound 4: middle estimate off by 1.0-fold (0.01 log units), on the high side; the measured number falls inside the stated range.
By their numbers in this assay, from the lowest: compound 1; then compounds 2, 3 and 4 (each within the scatter of the next, the first and the last beyond it).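

In this assay, putting 3-methylphenyl in place of cyclohexylmethyl on this nitrogen gives a 1.4-fold higher number from compound 3 to compound 4 (0.14 log units; within the scatter), so the two groups cannot be told apart by this read-out. The earlier step at the same nitrogen, a 22-fold higher number from compound 1 to compound 2 (1.34 log units; beyond the scatter), showed that the group here can matter a great deal, but this new step shows that not every change at this place does: a six-membered non-aromatic ring gives way to a six-membered aromatic one, with the group still holding seven carbon atoms, and the number stays within the scatter. No measurement is available that would explain why this exchange of rings leaves the number so little changed.

The compounds shown leave open how the number responds on this nitrogen to other groups, such as a plain phenyl, a small methyl, or a ring carrying an amine or a carboxylic acid. They also leave open whether cyclopentyl, the group on this nitrogen in compound 1, would keep its much lower number in this assay if the chloro were present as well.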